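A few compounds are considered here, and "the series" means these few. Any claim that something is new, unique, unknown or untested is made for them only; others in the source may bear on it.

Compound 1 `O=C1COC(c2ccc(/N=C/c3ccc(Cl)cc3)cc2)=NN1` and compound 2 `Cc1cccc(/C=N/c2ccc(C3=NNC(=O)CO3)cc2)c1` share one core, and compound 3 `O=C1COC(c2ccc(/C=C/c3ccc(Cl)cc3)cc2)=NN1` and compound 4 `Cc1cccc(/C=C/c2ccc(C3=NNC(=O)CO3)cc2)c1` share another; the difference between the two cores is not broken down here. In an assay on cells for inhibition of Amine oxidase [flavin-containing] B (Homo sapiens), read by Amplex Red, with a stated time of 30 min (a lower number here means a stronger inhibitor, a higher number a weaker inhibitor), compound 1 gives 433 nM, compound 2 gives 1270 nM, and compound 3 gives 542 nM. Within the first pair the change is 3-methylphenyl in place of 4-chlorophenyl on a carbon with a double bond to nitrogen and it produced a 2.9-fold higher number from compound 1 to compound 2 (0.47 log units; beyond the scatter). The same kind of change carries compound 3 to compound 4: 3-methylphenyl in place of 4-chlorophenyl on a double-bonded chain carbon bound to a double-bonded chain carbon. The place is not the same in words, since in the first pair the group sits on a carbon with a double bond to nitrogen whose other neighbours are a double-bonded nitrogen, while in the second it sits on a double-bonded chain carbon bound to a double-bonded chain carbon. Compound 4 is not yet measured in this assay. Because compound 1 to compound 2 gave a 2.9-fold higher number from compound 1 to compound 2 (0.47 log units; beyond the scatter), a step of about the same size, a 2.8-fold higher number from compound 3 to compound 4 (0.44 log units; beyond the scatter), is expected from compound 3 to compound 4. Compound 4 is therefore estimated at 1500 nM, most likely between 700 nM and 3500 nM.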

Compound 4, half-maximal inhibitory concentration: 338 nM
Compound 4: middle estimate off by 4.4-fold (0.65 log units), on the high side, outside the stated range (below it).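

In this assay, putting 3-methylphenyl in place of 4-chlorophenyl on the core of compound 3 gave a 1.6-fold lower number from compound 3 to compound 4 (0.21 log units; within the scatter) and so did not repeat the clear rise in the number seen on the core of compound 1. The same change therefore gave different results on the two cores: the same change on two cores in this assay, a 2.9-fold higher number (0.47 log units; beyond the scatter) from compound 1 to compound 2 and a 1.6-fold lower number (0.21 log units; within the scatter) from compound 3 to compound 4, 4.7-fold (0.67 log units) apart, beyond the scatter of two such steps. Among these compounds, this shows that a step measured on one core cannot simply be carried over to the other, but it rests on only two steps with one pair of groups, and it does not show which part of the difference between the cores is responsible or whether other changes would carry over.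

The compounds shown leave open how a phenyl ring carrying an amine or a carboxylic acid would behave on either core. They also leave open whether the two cores would again part ways with a longer chain in place of the double-bonded chain.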